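Moving a fluorine on the benzoyl ring of compound 1

The source may report more compounds than this note shows. Statements on the series, on what has been measured and on what is new or still open speak of the compounds shown alone.

Three compounds sharing a thiosemicarbazide linker to a quinazoline-type core have been tested in a functional assay on CNE-2 cells (Homo sapiens) for cytotoxicity, read by MTT assay, with a stated time of 72 h; on this read-out lower numbers stand for stronger inhibition and higher numbers for weaker inhibition. Compound 1 `COc1cc2ncnc(NNC(=S)NC(=O)c3ccc(F)cc3)c2cc1OC` gives 16100 nM, the highest number of the three and therefore the weakest inhibitor in this set. Compound 2 `O=C(NC(=S)NNc1ncnc2ccccc12)c1ccccc1Cl` gives 6090 nM, and compound 3 `O=C(NC(=S)NNc1ncnc2ccccc12)c1ccccc1` gives 1490 nM. Among the measured compounds shown here, the only single-point step among the measured compounds is a 4.1-fold lower number from compound 2 to compound 3 (0.61 log units; beyond the scatter), which shows that removing a chloro from the benzoyl ring lowers the number beyond the scatter.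

Compound 4 `COc1cc2ncnc(NNC(=S)NC(=O)c3ccccc3F)c2cc1OC` keeps every atom of compound 1 but joins them differently: 2-fluorophenyl in place of 4-fluorophenyl on a carbonyl carbon. For the measured compounds named here, no measured pair shows exactly this move of a fluorine from one ring position to another. The step of a 4.1-fold lower number from compound 2 to compound 3 (0.61 log units; beyond the scatter) bears on it only loosely, since it compares a 2-chlorophenyl with a plain phenyl, not two fluorophenyl groups; it hints that a substituent at the 2-position may raise the number, but the evidence is indirect. The expectation is therefore a small shift toward a higher number, possibly within the scatter, giving a 1.4-fold higher number from compound 1 to compound 4 (0.14 log units; within the scatter). Compound 4 is estimated at 22000 nM, with a range from 9000 nM to 55000 nM.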

Compound 4, half-maximal inhibitory concentration: 12700 nM
Beside the measured number, compound 4's estimate is 1.7-fold (0.24 log units) above it; low and high end bracket the measured number.
By their numbers in this assay, from the lowest: compound 3; then compound 2; then compounds 4 and 1 (each within the scatter of the next).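

In this assay, exchanging 4-fluorophenyl for 2-fluorophenyl on a carbonyl carbon gives a 1.3-fold lower number from compound 1 to compound 4 (0.10 log units; within the scatter) and so leaves no readable change: on the core of compound 1, this read-out does not separate these two placements of the fluorine. Among the compounds shown here, the earlier compounds offered only a 4.1-fold lower number from compound 2 to compound 3 (0.61 log units; beyond the scatter) as a single-place step, which takes a chloro away on a different core, whereas this new pair keeps the atoms the same and changes only where the fluorine sits, adding a first comparison of that kind. No measurement is available here that would offer an explanation for this result.

The compounds shown leave open what the fluorine itself contributes, since no compound with the core of compound 1 carries a plain phenyl on the carbonyl carbon, so a step like the one from compound 2 to compound 3 cannot be read there. Also open, on these data alone, is how a different group on that ring, such as an amine or a carboxylic acid, would behave, and whether the 3-fluorophenyl isomer would match the two fluorophenyl compounds.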